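Cytotoxicity expectation for a 2,3-difluorophenyl variant

A few compounds are considered here, and "the series" means these few. Any claim that something is new, unique, unknown or untested is made for them only; others in the source may bear on it.

The measured compounds in a toxicity assay on Vero cells (Chlorocebus sabaeus) for cytotoxicity; on this read-out higher numbers stand for lower toxicity in this test and lower numbers for higher toxicity in this test:

Compound 1, `COc1ncc(-c2ccccc2)cc1[C@@H](c1ccccc1)[C@@](O)(CCN(C)C)c1cc(F)ccc1F`, gives a limit of the assay, > 50 ug/mL.
Compound 2, `COc1ncc(-c2ccccc2)cc1[C@@H](c1ccccc1)[C@@](O)(CCN(C)C)c1cc(F)cc(F)c1`, gives a limit of the assay, > 50 ug/mL.
Compound 3, `COc1ncc(-c2ccccc2)cc1[C@@H](c1ccccc1)[C@@](O)(CCN(C)C)c1ccccc1`, gives a limit of the assay, > 50 ug/mL.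

In this assay, for the measured compounds named here, compound 3 stands only at a limit, and the two other values shown are limits as well, so no compound has a number. The change from compound 3 to compound 4, `COc1ncc(-c2ccccc2)cc1[C@@H](c1ccccc1)[C@@](O)(CCN(C)C)c1cccc(F)c1F`, is 2,3-difluorophenyl in place of phenyl on a saturated chain carbon bound to an oxygen on a saturated carbon and two saturated chain carbons. Going by the values given here, three measured steps concern the same place: a step that the two limits leave unreadable from compound 1 to compound 2, a step that the two limits leave unreadable from compound 1 to compound 3 and a step that the two limits leave unreadable from compound 2 to compound 3. None of them can be read in size or direction, since (the limit of > 50 ug/mL in this assay, at which 3 of the 3 values shown sit). The steps between difluorophenyl and phenyl groups at this place therefore give no readable size to carry over, and no step beyond the scatter is expected here; the expected step is a step that the limit leaves unreadable from compound 3 to compound 4. Compound 4 is thus estimated to give 60 ug/mL, with a range from 30 ug/mL to 120 ug/mL, most likely again only a limit.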

Compound 4, half-maximal cytotoxic concentration: > 50 ug/mL
Compound 4 gave a limit, no number; the forecaster's own chance of this, stated with the estimate: 85%; the middle value lies beyond the limit too.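

In this assay compound 4 gives > 50 ug/mL, which is a limit and not a number. Its steps from compound 1, compound 2 and compound 3 therefore cannot be read: the limit of > 50 ug/mL in this assay, at which 4 of the 4 values shown sit. The compounds shown leave open whether changing the fluorine pattern on this phenyl group shifts the half-maximal cytotoxic concentration at all.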